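A few compounds are considered here, and "the series" means these few. Any claim that something is new, unique, unknown or untested is made for them only; others in the source may bear on it.

Working notes on the series in a functional assay on NCI-H1975 cells (Homo sapiens) for inhibition, read by sulforhodamine B assay, tested at 10 uM; on this read-out higher numbers stand for more inhibition at the one concentration tested (going by the name of the read-out) and lower numbers for less inhibition.

The parent, compound 1 `CN(C)c1ccc(C2CC(c3ccc(-n4cncn4)cc3)=NN2)cc1`, with hydrogen on the amine nitrogen in the ring, gives -3.3%. Compound 2 `CN(C)c1ccc(C2CC(c3ccc(-n4cncn4)cc3)=NN2C(=O)c2cc(Cl)cc(Cl)c2)cc1` carries (3,5-dichlorophenyl)carbonyl there and gives 8.4%; the step of a number 11.7 percentage points higher from compound 1 to compound 2 (beyond the scatter) is the only one beyond the scatter. Compound 3 `CN(C)c1ccc(C2CC(c3ccc(-n4cncn4)cc3)=NN2S(=O)(=O)c2ccc(Br)cc2)cc1` carries (4-bromophenyl)sulfonyl and gives -0.6%. Among the measured compounds shown here, compound 3 sits nearest compound 1 and further from compound 2, yet a number 2.7 percentage points higher from compound 1 to compound 3 (within the scatter) and a number 9 percentage points lower from compound 2 to compound 3 (within the scatter) both stay within the scatter, so no ordering among compound 1, compound 3 and compound 2 is secure beyond the one step noted.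

Compound 4 `CN(C)c1ccc(C2CC(c3ccc(-n4cncn4)cc3)=NN2S(=O)(=O)c2ccc(C#N)cc2)cc1` differs from compound 3 as follows: cyano in place of bromo on an aromatic carbon. For the measured compounds named here, no measured step touches the para substituent of the phenylsulfonyl group; the steps that involve this group, a number 2.7 percentage points higher from compound 1 to compound 3 (within the scatter) and a number 9 percentage points lower from compound 2 to compound 3 (within the scatter), are both small. Every measured number in this assay lies close to zero inhibition. For compound 4 the expected step is therefore a number 1.6 percentage points higher from compound 3 to compound 4 (within the scatter), none beyond the scatter. The estimate for compound 4 in this assay is 1%, in the range -11% to 13%.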

Compound 4, a percentage reported as inhibition, at one concentration (the size of the read-out at that concentration, not a potency): 22.6%
For compound 4 the middle estimate is 21.6 percentage points below the measured one, outside the stated range (above it).
By their numbers in this assay, from the lowest: compounds 1, 3 and 2 (each within the scatter of the next, the first and the last beyond it); then compound 4.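

In this assay, among the compounds shown here, the aromatic carbon para to a large group proves responsive: cyano in place of bromo gives a step beyond the scatter (a number 23.2 percentage points higher from compound 3 to compound 4 (beyond the scatter)), at a place no earlier pair touched. The (4-cyanophenyl)sulfonyl group also stands clear of both the hydrogen (a number 25.9 percentage points higher from compound 1 to compound 4 (beyond the scatter)) and the (3,5-dichlorophenyl)carbonyl group (a number 14.2 percentage points higher from compound 2 to compound 4 (beyond the scatter)), so a sulfonyl group on the amine nitrogen in the ring does not by itself tie the series to the near-zero numbers. No measurement at hand bears on what lies behind this step.

Open, from the compounds shown here alone, is whether the rise is particular to cyano or also appears with an amine, a carboxylic acid or a methoxy group on the same carbon. Also open, going by these compounds, is whether cyano on the phenyl ring of the carbonyl group of compound 2 would give a comparable step.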